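Aryl swap on the ring nitrogen: compound 3 to compound 4

The source may report more compounds than this note shows. Statements on the series, on what has been measured and on what is new or still open speak of the compounds shown alone.

Measured so far:
- compound 1 `Cc1ccccc1-n1nncc1CN1C(=O)C2(C(C#N)=C(N)Oc3c(N)cc4nc5ccccc5nc4c32)c2ccccc21` gives 31700 nM in a functional assay on A549 cells (Homo sapiens) for antiproliferative activity, read by MTT assay, with a stated time of 48 h; a higher number here means a weaker inhibitor, a lower number a stronger inhibitor
- compound 2 `Cc1ccc(C)c(-n2nncc2CN2C(=O)C3(C(C#N)=C(N)Oc4c(N)cc5nc6ccccc6nc5c43)c3ccccc32)c1` reaches only a limit in this assay, namely > 50000 nM
- compound 3 `N#CC1=C(N)Oc2c(N)cc3nc4ccccc4nc3c2C12C(=O)N(Cc1cnnn1-c1ccc(Cl)cc1Cl)c1ccccc12` likewise reaches only a limit in this assay, namely > 50000 nM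

Compound 3 therefore stands at the edge of what this assay reports, together with compound 2, see (the limit of > 50000 nM in this assay, at which 2 of the 3 values shown sit). Compound 4 `N#CC1=C(N)Oc2c(N)cc3nc4ccccc4nc3c2C12C(=O)N(Cc1cnnn1-c1cc(Cl)ccc1Cl)c1ccccc12` is not yet measured; it differs from compound 3 by 2,5-dichlorophenyl in place of 2,4-dichlorophenyl on an aromatic nitrogen.

Going by the values given here, two measured steps touch the same aromatic nitrogen: an at least 1.5-fold higher number from compound 1 to compound 3 (0.19 log units; that floor lies within the scatter) and a step that the two limits leave unreadable from compound 2 to compound 3. The remaining step, an at least 1.5-fold higher number from compound 1 to compound 2 (0.19 log units; that floor lies within the scatter), is a methyl addition elsewhere. Among the compounds with values here, none of the three changes at this position has moved the number downward; the one readable step points upward, to the limit. Moving one chlorine within the same dichlorophenyl ring is a smaller change than either of those, so no step beyond the scatter is expected in this assay, and compound 4 is expected to sit at or near the limit.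

Compound 4 is estimated at 60000 nM, range 20000 nM to 180000 nM, which is expected to mean a step that the limit leaves unreadable from compound 3 to compound 4.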

Compound 4, half-maximal inhibitory concentration: 10900 nM
Compound 4: middle estimate off by 5.5-fold (0.74 log units), on the high side, outside the stated range (below it).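

In this assay, going by these compounds alone, the same atoms joined differently give an at least 4.5-fold lower number from compound 3 to compound 4 (0.66 log units; beyond the scatter), so the place of one chlorine on the phenyl ring counts on this aromatic nitrogen, which the earlier compounds did not show. Within the data shown here, the 2,5-dichlorophenyl group also separates from its dimethyl counterpart, with an at least 4.5-fold lower number from compound 2 to compound 4 (0.66 log units; beyond the scatter), and it gives the first downward step at this nitrogen, with a 2.9-fold lower number from compound 1 to compound 4 (0.46 log units; beyond the scatter). Two of these steps are floors, not full sizes, since each starts from a limit: the limit of > 50000 nM in this assay, at which 2 of the 4 values shown sit.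

The compounds shown leave open whether a phenyl ring carrying a single chlorine, or methoxy groups in place of the chlorines, would follow compound 4 or fall back to the limit. They also leave open whether the step from the moved chlorine holds on any other cells.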